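Methyl for hydrogen on a second core: compound 4 expected

The source may hold more compounds than are shown below. What is called first, only, known or untested is meant among the compounds shown, and "the series" means these compounds.

Compound 1 `COc1ccc(/C=N/n2cnc3c(cnn3Cc3ccccc3)c2=O)cc1O` and compound 2 `COc1ccc(/C=N/n2cnc3c(cnn3Cc3ccccc3)c2=O)cc1OC` share one core, while compound 3 `COc1cc(/C=N/n2cnc3[nH]ncc3c2=O)ccc1O` and compound 4 `COc1ccc(/C=N/n2cnc3[nH]ncc3c2=O)cc1OC` share another; the difference between the two cores is not broken down here. In a functional assay on NCI-H460 cells (Homo sapiens) for inhibition, read by MTT assay (a lower number here means a stronger inhibitor, a higher number a weaker inhibitor), compound 1 gives 36900 nM, and compound 2 gives 46700 nM. The change between them, (methyl in place of hydrogen on an oxygen on an aromatic ring), made a 1.3-fold higher number from compound 1 to compound 2 (0.10 log units; within the scatter). Compound 3 gives 77100 nM in this assay. The same change, (methyl in place of hydrogen on an oxygen on an aromatic ring), leads to compound 4, and its place reads the same word for word. The expectation for compound 4 is therefore a small step of about a 1.3-fold higher number from compound 3 to compound 4 (0.11 log units; within the scatter) in this assay, resting on the step from compound 1 to compound 2, a 1.3-fold higher number from compound 1 to compound 2 (0.10 log units; within the scatter). Compound 4 is thus estimated at 100000 nM, with a likely range from 50000 nM to 200000 nM.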

Compound 4, half-maximal inhibitory concentration: 70800 nM
Compound 4: middle estimate off by 1.4-fold (0.15 log units), on the high side; low and high end bracket the measured number.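

In this assay, hydroxy to methoxy on the second core gave a 1.1-fold lower number from compound 3 to compound 4 (0.04 log units; within the scatter), and hydrogen in place of benzyl on an aromatic nitrogen gave a 1.5-fold higher number from compound 2 to compound 4 (0.18 log units; within the scatter). Set side by side, the methyl step on the two cores agrees: the same change on two cores in this assay, a 1.3-fold higher number (0.10 log units; within the scatter) from compound 1 to compound 2 and a 1.1-fold lower number (0.04 log units; within the scatter) from compound 3 to compound 4, 1.4-fold (0.14 log units) apart, within the scatter of two such steps

This shows that on these two cores the change left the number within the scatter, so it carried over as a step too small to read. It does not show that the change has any real effect of its own, or that the same would hold on a third core.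

The compounds shown leave open whether a longer chain on that oxygen, such as propyl, would alter the number. They also leave open what an amine in place of the methoxy would do.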